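Two Methoxy Groups in Place of One on the Benzamide

The source may report more compounds than this note shows. Statements on the series, on what has been measured and on what is new or still open speak of the compounds shown alone.

Of the compounds shown here, three that share one core have been measured. Compound 1 `CN(C)c1ccc(C(=O)N(CCC(=O)NCc2ccc(Cl)cc2)Cc2ccc(C(=O)NO)cc2)cc1` gives 10 nM in an assay on Sf9 cells for inhibition of protein deacetylase HDAC6 (Homo sapiens), read by fluorescence, with stated times of 90 min and 30 min; a higher number here means a weaker inhibitor, a lower number a stronger inhibitor. Within the data shown here, compound 3 `Cc1ccc(NC(=O)CCN(Cc2ccc(C(=O)NO)cc2)C(=O)c2ccc(N(C)C)cc2)cc1` gives 19.5 nM in this assay, and the only single-point step among the measured compounds, a 2.0-fold higher number from compound 1 to compound 3 (0.29 log units; within the scatter), changes the group on the amide-type nitrogen and stays within the scatter. Compound 2 `COc1ccc(C(=O)N(CCC(=O)NCc2ccccc2)Cc2ccc(C(=O)NO)cc2)cc1` gives 25.3 nM in this assay, the highest of the three numbers: its gap to compound 3 lies within the scatter, while its gap to compound 1 lies beyond it.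

Compound 4 `COc1cc(OC)cc(C(=O)N(CCC(=O)NCc2ccccc2)Cc2ccc(C(=O)NO)cc2)c1` is not yet measured. It differs from compound 2 in one place: 3,5-dimethoxyphenyl in place of 4-methoxyphenyl on a carbonyl carbon. Among the measured compounds shown here, no measured step touches this part of the molecule; the one measured step, a 2.0-fold higher number from compound 1 to compound 3 (0.29 log units; within the scatter), concerns the other end of the core and was small. With nothing to point either way, the plain expectation is that compound 4 will land close to compound 2. For compound 4 the expected step is a 1.0-fold lower number from compound 2 to compound 4 (0.01 log units; within the scatter), nothing beyond the scatter. Compound 4 is therefore estimated to give 25 nM in this assay, with a range from 10 nM to 65 nM to cover the uncertainty of an untested change.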

Compound 4, half-maximal inhibitory concentration: 26 nM
Compound 4: middle estimate off by 1.0-fold (0.02 log units), on the low side, and the stated range covers the measured number.
By their numbers in this assay, from the lowest: compounds 1, 3, 2 and 4 (each within the scatter of the next, the first and the last beyond it).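

In this assay, among these compounds, the swap of 4-methoxyphenyl for 3,5-dimethoxyphenyl on the carbonyl carbon gives a 1.0-fold higher number from compound 2 to compound 4 (0.01 log units; within the scatter) and is the first measured step at this position, since the earlier step concerned the other end of the core. It shows that, for this one pair, the group on this carbonyl carbon can grow from 8 to 10 heavy atoms and from 1 to 2 hydrogen-bond acceptors, and can carry its methoxy groups at different ring positions, while the two numbers remain indistinguishable. Nothing measured here explains why the two compounds read alike, so this result records what was observed and not its cause.

The pair leaves open how far this tolerance extends, as both groups carry only methoxy substituents, and a carboxylic acid or an amine on the ring could give a very different number. It also remains open whether 3,5-dimethoxyphenyl would read the same alongside the 4-chlorobenzyl group of compound 1, whose number is the lowest of those shown.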